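This account rests on a few compounds, and the source may have more. Where it says the series, first, only, none or still open, it means among the compounds named here.

In a functional assay on ID8 cells (Mus musculus) for antiproliferative activity (a higher number here means a weaker inhibitor, a lower number a stronger inhibitor), compound 1 `O=C(Nc1ccc(O)c2c(=O)cc(-c3ccccc3Cl)oc12)c1ccccc1` gives 13000 nM, compound 2 `CC(C)C[C@@H](NC(=O)OC(C)(C)C)C(=O)Nc1ccc(O)c2c(=O)cc(-c3ccccc3Cl)oc12` gives 17000 nM and compound 3 `C[C@H](NC(=O)OC(C)(C)C)C(=O)Nc1ccc(O)c2c(=O)cc(-c3ccccc3Cl)oc12` gives 9800 nM. These three values lie within the scatter of one another, so compound 3 does not stand apart from the other two on these numbers.

The next structure is compound 4 `CC(C)C[C@H](NC(=O)OC(C)(C)C)C(=O)Nc1ccc(O)c2c(=O)cc(-c3ccccc3Cl)oc12`, and the change is isopropyl in place of hydrogen on a saturated chain carbon, two bonds along the chain from an amide-type nitrogen and a carbonyl carbon. Isopropyl takes the place of hydrogen on a saturated chain carbon, two bonds along the chain from an amide-type nitrogen and a carbonyl carbon. Cut one bond further out, this reads methyl to isobutyl.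

Among the compounds with values here, the only measured step in the set is at a different place: a 1.3-fold lower number from compound 1 to compound 3 (0.12 log units; within the scatter), with 1-((tert-butoxycarbonyl)amino)ethyl in place of phenyl on a carbonyl carbon. It shows that a large replacement there did not move this assay beyond the scatter. More direct evidence comes from compound 2, which carries the same isobutyl with the opposite configuration at that chain carbon and gives 17000 nM. Within the data shown here, no pair in the set isolates that configuration, so the range is kept wide.

No step beyond the scatter is expected, and no direction is favoured. The expected change is a 1.3-fold higher number from compound 3 to compound 4 (0.12 log units; within the scatter). For compound 4 the estimated value is 13000 nM, with an expected range of 6000 nM to 28000 nM.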

Compound 4, half-maximal inhibitory concentration: 5100 nM
Estimate against measurement, compound 4: 2.5-fold (0.41 log units) above; measured number below the stated range.
By their numbers in this assay, from the lowest: compounds 4, 3, 1 and 2 (each within the scatter of the next, the first and the last beyond it).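

In this assay, within the data shown here, the configuration at the saturated chain carbon, two bonds along the chain from an amide-type nitrogen and a carbonyl carbon, gives the one step that lies beyond the scatter, modest in size, a 3.3-fold lower number from compound 2 to compound 4 (0.52 log units; beyond the scatter), and this step can be read on the stereocentre alone: the fact that compounds 2 and 4 differ only in the configuration as drawn. Isopropyl in place of hydrogen at the same carbon, which reads as methyl to isobutyl, gives a 1.9-fold lower number from compound 3 to compound 4 (0.28 log units; within the scatter), so the larger chain is tolerated with the configuration of compound 4, with no change that separates from the scatter. The earlier compounds shown here offered no matched pair at this stereocentre, so only compound 2 and compound 4 show that the R and S forms of the isobutyl compound can be told apart here.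

Open, on these data alone, is whether configuration at this carbon has the same bearing with methyl, and whether an amine, a carboxylic acid or a longer chain in place of isobutyl would move the number beyond the scatter. Also open, as far as these compounds go, is whether a free amine in place of the tert-butoxycarbonyl amino group would keep the difference between the two configurations.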